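From chloro to bromo on compound 1

The source may report more compounds than this note shows. Statements on the series, on what has been measured and on what is new or still open speak of the compounds shown alone.

In a functional assay on NCI-H1975 cells (Homo sapiens) for antiproliferative activity, with a stated time of 72 h (a lower number here means a stronger inhibitor of growth, a higher number a weaker inhibitor of growth), compound 1 (`COc1cc(CN(C)C(=O)c2cc(Cl)c(O)cc2O)c(Cl)c(OC)c1OC`) stands at 33800 nM and sits within the scatter of the two other measured compounds. Compound 2 (`Cc1cccc(CN(C)C(=O)c2cc(Cl)c(O)cc2O)c1`) reads 49300 nM and compound 3 (`CCNC(=O)c1ccc(CN(C)C(=O)c2cc(Cl)c(O)cc2O)cc1`) reads 21700 nM in the same test. Compound 4 (`COc1cc(CN(C)C(=O)c2cc(Cl)c(O)cc2O)c(Br)c(OC)c1OC`) awaits measurement. It departs from compound 1 by a single change (bromo in place of chloro on an aromatic carbon) in which bromo takes the place of chloro on an aromatic carbon, ortho to a large group. Among the compounds with values here, no measured pair shows this exchange, so the data give it no direction. A step in this assay no larger than the scatter is expected, either way. For compound 4 the estimated value is 30000 nM (expected range 16000 nM to 55000 nM).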

Compound 4, concentration for 50% growth inhibition: 34300 nM
For compound 4 the middle estimate is 1.1-fold (0.06 log units) below the measured one; measured number inside the range.
By their numbers in this assay, from the lowest: compounds 3, 1, 4 and 2 (each within the scatter of the next, the first and the last beyond it).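

In this assay bromo in place of chloro on this aromatic carbon, ortho to a large group, gives a 1.0-fold higher number from compound 1 to compound 4 (0.01 log units; within the scatter) and stays within the scatter. Within the data shown here, this pair is the first to show the exchange directly, and at this position the two halogens cannot be told apart in this test. Nothing shown explains this result.

On these data alone, what hydrogen, fluoro, an amine or a carboxylic acid on this carbon would do stays open. So does whether the same exchange would read alike on a different core.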